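Swapping the amine arm on compound 3 for a piperidine

A few compounds are considered here, and "the series" means these few. Any claim that something is new, unique, unknown or untested is made for them only; others in the source may bear on it.

Of the compounds shown here, three have been measured in a functional assay on Bel-7402 cells (Homo sapiens) for antiproliferative activity, with a stated time of 72 h; on this read-out higher numbers stand for weaker inhibition and lower numbers for stronger inhibition. Going by the values given here, compound 1 `COc1cc(O)c2c(=O)cc(-c3ccccc3Cl)oc2c1CN1CCCCC1` gives 118000 nM, and compound 2 `COc1cc(OC)c2c(=O)cc(-c3ccccc3Cl)oc2c1CN1CCCCC1` gives 44200 nM; the step of a 2.7-fold lower number from compound 1 to compound 2 (0.43 log units; beyond the scatter) is the only single-point change among the measured pairs. Compound 3 `COc1cc(OC)c(C(=O)/C=C/c2ccccc2Cl)c(O)c1CN(C)CCCN(C)C`, built on a different core, gives 30900 nM in this assay; that number sits within the usual scatter of compound 2 and well below compound 1.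

Compound 4 `COc1cc(OC)c(C(=O)/C=C/c2ccccc2Cl)c(O)c1CN1CCCCC1` differs from compound 3 in one place: piperidin-1-yl in place of (3-(dimethylamino)propyl)(methyl)amino on a saturated chain carbon bound to an aromatic carbon. Among the compounds with values here, no measured pair shows this kind of change, and the only measured step concerns a hydroxyl being methylated on a different core, so it does not bear on the amine swap. With nothing in the data to anchor a direction, no shift beyond the scatter is expected, and the step of a 1.0-fold higher number from compound 3 to compound 4 (0.02 log units; within the scatter) is estimated as essentially flat. Compound 4 is therefore expected to give about 32000 nM in this assay, with a range from 12000 nM to 85000 nM.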

Compound 4, half-maximal inhibitory concentration: 3100 nM
Beside the measured number, compound 4's estimate is 10-fold (1.01 log units) above it; measured number below the stated range.
By their numbers in this assay, from the lowest: compound 4; then compounds 3 and 2 (each within the scatter of the next); then compound 1.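

The amine arm on the saturated chain carbon bound to an aromatic carbon clearly matters: in this assay, putting piperidin-1-yl in place of (3-(dimethylamino)propyl)(methyl)amino gives a 10-fold lower number from compound 3 to compound 4 (1.00 log units; beyond the scatter). Going by these compounds alone, the earlier step involved only a methyl on an oxygen, on a different core, so this is the first measured sign that this position can shift the number well beyond the scatter. Nothing measured here accounts for the size of this step.

The swap closes a ring and removes the second nitrogen in a single move, so this one step cannot show which of the two matters. A pyrrolidine or a morpholine at the same place, or a piperidine carrying a dimethylamino group, would help separate the two.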